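The source may hold more compounds than are shown below. What is called first, only, known or untested is meant among the compounds shown, and "the series" means these compounds.

Measured in a functional assay on MDA-MB-436 cells (Homo sapiens) for antiproliferative activity, read by MTT assay, with a stated time of 48 h; on this read-out lower numbers stand for stronger inhibition and higher numbers for weaker inhibition:
compound 1 `C=CS(=O)(=O)N1CCN(c2ncnc3sc(-c4ccc(N5CCN(C)CC5)cc4)cc23)CC1` gives 8760 nM
compound 2 `CN1CCN(c2ccc(-c3cc4c(N5CCN(S(=O)(=O)/C=C/c6ccccc6)CC5)ncnc4s3)cc2)CC1` gives 8670 nM
compound 3 `CN1CCN(c2ccc(-c3cc4c(N5CCN(C(=O)Nc6ccc(C#N)cc6)CC5)ncnc4s3)cc2)CC1` gives 5010 nM

Compound 3 is not separated from the other two compounds in this assay. The measured steps read a 1.7-fold lower number from compound 1 to compound 3 (0.24 log units; within the scatter) and a 1.7-fold lower number from compound 2 to compound 3 (0.24 log units; within the scatter).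

Compound 4 `CN1CCN(c2ccc(-c3cc4c(N5CCN(C(=O)Nc6cccc(F)c6)CC5)ncnc4s3)cc2)CC1` has not been measured. Its difference from compound 3 is 3-fluorophenyl in place of 4-cyanophenyl on an amide-type nitrogen. For the measured compounds named here, no measured step changes the aromatic group on that amide-type nitrogen, so the evidence is indirect. The closest evidence comes from replacing the whole group on the ring amine nitrogen, which gave a 1.7-fold lower number from compound 1 to compound 3 (0.24 log units; within the scatter) and a 1.7-fold lower number from compound 2 to compound 3 (0.24 log units; within the scatter). Changing the group on the sulfonyl sulfur gave a 1.0-fold lower number from compound 1 to compound 2 (0.00 log units; within the scatter). With all three steps inside the scatter, no step beyond the scatter is expected in this assay, in either direction. The expected change is a 1.1-fold higher number from compound 3 to compound 4 (0.04 log units; within the scatter). Compound 4 is estimated at 5500 nM, with an expected range of 2500 nM to 12000 nM.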

Compound 4, half-maximal inhibitory concentration: 18300 nM
Compound 4: middle estimate off by 3.3-fold (0.52 log units), on the low side; measured number above the stated range.
By their numbers in this assay, from the lowest: compounds 3, 2 and 1 (each within the scatter of the next); then compound 4.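

In this assay, for the compounds shown here, the aromatic group on the amide-type nitrogen turns out to count: 3-fluorophenyl in place of 4-cyanophenyl gives a 3.7-fold higher number from compound 3 to compound 4 (0.56 log units; beyond the scatter), the first step beyond the scatter. The replacements on the ring amine nitrogen, which stayed within the scatter with (4-cyanophenyl)carbamoyl, now read a 2.1-fold higher number from compound 2 to compound 4 (0.32 log units; beyond the scatter) and a 2.1-fold higher number from compound 1 to compound 4 (0.32 log units; beyond the scatter) with (3-fluorophenyl)carbamoyl, so the outcome of a carbamoyl group there depends on the aromatic group it carries. No measurement at hand accounts for this step.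

The step changes both the substituent and its place on the phenyl ring, and the compounds shown do not separate the two. Also open, on these data alone, is how a methoxy group, an amine or a carboxylic acid on that phenyl ring would read.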